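Same Atoms, Joined Differently: What Compound 4 Should Show

This account rests on a few compounds, and the source may have more. Where it says the series, first, only, none or still open, it means among the compounds named here.

Compound 1 `N/C(=N\O)c1ccc(S(=O)(=O)C2=C(c3ccc(Nc4cccc(/C(N)=N/O)c4)cc3)OC(c3ccccc3)(c3ccccc3)C2)cc1` and compound 3 `N/C(=N\O)c1ccc(S(=O)(=O)C2=C(c3ccc(Nc4ccccc4/C(N)=N/O)cc3)OC(c3ccccc3)(c3ccccc3)C2)cc1` share one core and differ only by a group of 10 heavy atoms (7 carbon, 2 nitrogen, 1 oxygen; one six-membered aromatic ring of carbon only) in place of a group of 10 heavy atoms (7 carbon, 2 nitrogen, 1 oxygen; one six-membered aromatic ring of carbon only), on a nitrogen on an aromatic ring. In an ADME assay on THP-1 cells (Homo sapiens) for cytotoxicity, read by flow cytometry, with a stated time of 72 h (on this read-out higher numbers stand for weaker inhibition and lower numbers for stronger inhibition), compound 1 gives 48100 nM, while compound 3 gives 47800 nM, so the change made a 1.0-fold lower number from compound 1 to compound 3 (0.00 log units; within the scatter). Compound 2 `CC1(Cc2ccccc2)CC(S(=O)(=O)c2ccc(Nc3cccc(/C(N)=N/O)c3)cc2)=C(c2ccc(/C(N)=N/O)cc2)O1` is built on a different core; the difference between the two cores is not broken down here. In this assay compound 2 gives 46600 nM, a number that sits within the scatter of both compound 1 and compound 3.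

Compound 4 `CC1(Cc2ccccc2)CC(S(=O)(=O)c2ccc(Nc3ccccc3/C(N)=N/O)cc2)=C(c2ccc(/C(N)=N/O)cc2)O1` has not yet been measured. Among the measured compounds shown here, it differs from compound 2 by a group of 10 heavy atoms (7 carbon, 2 nitrogen, 1 oxygen; one six-membered aromatic ring of carbon only) in place of a group of 10 heavy atoms (7 carbon, 2 nitrogen, 1 oxygen; one six-membered aromatic ring of carbon only), on a nitrogen on an aromatic ring, which is the same change as the one from compound 1 to compound 3, at the same kind of place. Since that earlier change produced a 1.0-fold lower number from compound 1 to compound 3 (0.00 log units; within the scatter), the expectation is that the step from compound 2 to compound 4 will be of similar size, a 1.0-fold higher number from compound 2 to compound 4 (0.00 log units; within the scatter). Compound 4 is therefore estimated at 47000 nM in this assay, with a likely range from 30000 nM to 70000 nM; this rests only on the three measured compounds above.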

Compound 4, half-maximal inhibitory concentration: 48400 nM
Estimate against measurement, compound 4: 1.0-fold (0.01 log units) below; measured number inside the range.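

In this assay, the same swap on the second core, one group for another made of the same atoms joined differently, gives a 1.0-fold higher number from compound 2 to compound 4 (0.02 log units; within the scatter). Set side by side, the two steps agree: the same change on two cores in this assay, a 1.0-fold lower number (0.00 log units; within the scatter) from compound 1 to compound 3 and a 1.0-fold higher number (0.02 log units; within the scatter) from compound 2 to compound 4, 1.0-fold (0.02 log units) apart, within the scatter of two such steps

This shows that, on these two cores and in this assay, the swap carries over as a change with no effect that can be told from the scatter; it does not show that a real effect of the swap would carry over, as neither step has one to compare, and a pair of near-zero steps is a weak test of transfer. It also says nothing about other cores or about any other kind of measurement.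

The compounds shown leave open whether a ring carrying a carboxylic acid or an amine, on that same nitrogen, would move the number beyond the scatter. They also leave open whether the swap would stay as quiet on a core bearing a longer chain.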